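The source may report more compounds than this note shows. Statements on the series, on what has been measured and on what is new or still open speak of the compounds shown alone.

The measured compounds:

Compound 1, `CCCCCCOc1ccc(-n2cnnc2)cc1`, gives 9.8 mg/kg in a functional assay on the whole organism (strain C57B/6) with Mus musculus as the target, in the maximal electroshock model; on this read-out higher numbers stand for an effect only at larger amounts of compound and lower numbers for an effect already at smaller amounts.
Compound 2, `CCCCCCOc1ccc(-n2cnnc2C)cc1`, gives 22.8 mg/kg.
Compound 3, `CCCCCCCc1nncn1-c1ccc(OCCCCCC)cc1`, gives only a limit of the assay, > 40 mg/kg.

Compound 3 therefore does not stand on a number at all but at the edge of what this assay reports (the limit of > 40 mg/kg in this assay, at which 1 of the 3 values shown sits); the steps leading to it are an at least 4.0-fold higher number from compound 1 to compound 3 (0.61 log units; beyond the scatter) and an at least 1.7-fold higher number from compound 2 to compound 3 (0.24 log units; that floor lies within the scatter). The step that follows keeps the shared core of compound 3 and changes one group: 2-chlorophenyl in place of heptyl on an aromatic carbon. The result is compound 4, `CCCCCCOc1ccc(-n2cnnc2-c2ccccc2Cl)cc1`, which is not yet measured.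

For the measured compounds named here, two measured steps bear on this position of the five-membered ring: a 2.3-fold higher number from compound 1 to compound 2 (0.37 log units; beyond the scatter) and an at least 4.0-fold higher number from compound 1 to compound 3 (0.61 log units; beyond the scatter). Both show that placing a group on that aromatic carbon raises the number, the heptyl more than the methyl. Nothing measured here tells how a 2-chlorophenyl behaves at that place, so a step beyond the scatter in either direction from compound 3 cannot be expected with confidence; the estimate for compound 4 is a number no higher from compound 3 to compound 4 (the limit leaves the size open), meaning it is expected to stay near the limit. Compound 4 is thus estimated at 40 mg/kg, within 15 mg/kg to 100 mg/kg.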

Compound 4, dose for half-maximal effect: 13.2 mg/kg
Compound 4: the middle estimate sits 3.0-fold (0.48 log units) above what was measured, outside the stated range (below it).
By their numbers in this assay, from the lowest: compounds 1, 4 and 2 (each within the scatter of the next, the first and the last beyond it). At a limit, above all of these: compound 3.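

At this aromatic carbon of the five-membered ring, the size of a group alone does not set the result in this assay: the 2-chlorophenyl and the heptyl have the same heavy-atom count, yet an at least 3.0-fold lower number from compound 3 to compound 4 (0.48 log units; beyond the scatter) is the step between them. Set against the hydrogen and the methyl at the same place, the 2-chlorophenyl leaves no difference that can be told from scatter, as both a 1.3-fold higher number from compound 1 to compound 4 (0.13 log units; within the scatter) and a 1.7-fold lower number from compound 2 to compound 4 (0.24 log units; within the scatter) show. The rise in the number seen with the methyl and the heptyl is therefore no rule for every group at this place, and compound 4 is the compound that goes against it.

Going by these compounds, whether a plain phenyl without the chlorine, a butyl chain or an amine at this place would behave like the 2-chlorophenyl stays open. How large the step from the heptyl really is also stays open, since compound 3 stands only at a limit: the limit of > 40 mg/kg in this assay, at which 1 of the 4 values shown sits.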